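The compounds below may be only part of what the source reports. "The series", "measured", "known", "first", "only" and "open" are said of these compounds alone.

Measured so far in an assay on CHO cells for binding affinity to adenosine receptor A1 (Homo sapiens), read by TR-FRET, with a stated time of 2 h; a higher number here means a weaker inhibitor, a lower number a stronger inhibitor:
- compound 1 `Cc1cccnc1CNC(=O)c1cnc(-c2ccco2)nc1N` gives 1720 nM
- compound 2 `Cc1cccnc1CNC(=O)c1c(N)nc(-c2ccco2)nc1OC[C@H](C)O` gives 1.7 nM

Among the compounds with values here, compound 2 holds the lowest of the two numbers in this assay; its only neighbour is compound 1, and the step of a 1000-fold lower number from compound 1 to compound 2 (3.01 log units; beyond the scatter) came with 2-hydroxypropoxy in place of hydrogen on an aromatic carbon.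

Compound 3 `Cc1cccnc1CNC(=O)c1c(N)nc(-c2ccco2)nc1OCCF` is the next candidate, not yet measured. Relative to compound 2 the change is fluoromethyl in place of 1-hydroxyethyl on a saturated chain carbon bound to an oxygen on an aromatic ring. Within the data shown here, the alkoxy chain on the aromatic oxygen is kept, so the large gain seen in a 1000-fold lower number from compound 1 to compound 2 (3.01 log units; beyond the scatter) should largely carry over; what is lost is the hydroxyl of compound 2, and the only measured step does not separate the contribution of the chain from that of its hydroxyl. The expected outcome for compound 3 is therefore a modest rise in the number, a 3.5-fold higher number from compound 2 to compound 3 (0.55 log units; beyond the scatter), that may or may not clear the scatter. The estimate for compound 3 in this assay is 6 nM, with a range from 1.5 nM to 30 nM.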

Compound 3, inhibition constant: 260 nM
Estimate against measurement, compound 3: 43-fold (1.64 log units) below, and the stated range ends below it.
By their numbers in this assay, from the lowest: compound 2; then compound 3; then compound 1.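

In this assay the gain at this aromatic carbon turns out to depend on the make-up of the chain and not only on its presence: with 2-fluoroethoxy in place of 2-hydroxypropoxy, the series shows a 150-fold higher number from compound 2 to compound 3 (2.18 log units; beyond the scatter). The 2-fluoroethoxy chain still keeps part of the gain over hydrogen, with a 6.6-fold lower number from compound 1 to compound 3 (0.82 log units; beyond the scatter), a much smaller step than a 1000-fold lower number from compound 1 to compound 2 (3.01 log units; beyond the scatter), so an alkoxy chain as such does not reproduce the full effect of 2-hydroxypropoxy. No evidence at hand accounts for the size of this loss.

The change from compound 2 to compound 3 removes the hydroxyl and the defined stereocentre, shortens the chain and brings in fluorine all at once, so the compounds shown leave open which of these differences carries the loss. On these data alone, a 2-hydroxyethoxy chain, a 2-fluoropropoxy chain, the opposite stereoisomer of 2-hydroxypropoxy, a 2-methoxypropoxy chain, a 2-aminopropoxy chain and a longer hydroxyalkoxy chain would each bear on that question, and their numbers remain open here.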